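The source may report more compounds than this note shows. Statements on the series, on what has been measured and on what is new or still open speak of the compounds shown alone.

Among the compounds with values here, compound 2, `CC(=O)c1cc(-c2ccccc2)c2ccc(OCc3cccc(C4(O)CCOCC4)c3)cc2c1`, has the lower of the two numbers so far in an assay on isolated protein with Polyunsaturated fatty acid 5-lipoxygenase (Homo sapiens) as the target (on this read-out higher numbers stand for weaker inhibition and lower numbers for stronger inhibition), where compound 2 gives 130 nM. Compound 1, `COC(C)c1cc(-c2ccccc2)c2ccc(OCc3cccc(C4(O)CCOCC4)c3)cc2c1`, gives 1200 nM in this assay. Within the data shown here, the only step in hand, a 9.2-fold lower number from compound 1 to compound 2 (0.97 log units; beyond the scatter), shows that the group on that aromatic carbon matters. Compound 3, `OC1(c2cccc(COc3ccc4c(-c5ccccc5)cc(-c5nn[nH]n5)cc4c3)c2)CCOCC1`, differs from compound 2 by 2H-tetrazol-5-yl in place of acetyl on an aromatic carbon. Among the measured compounds shown here, no measured step swaps an acetyl for a 2H-tetrazol-5-yl, so the direction is uncertain. Compound 3 is expected to give about 300 nM, between 60 nM and 1500 nM, meaning an estimated 2.3-fold higher number from compound 2 to compound 3 (0.36 log units; beyond the scatter).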

Compound 3, half-maximal inhibitory concentration: > 6000 nM
Compound 3 ended at the assay's limit; the forecaster's own chance of this, stated with the estimate: 5%; at least 20-fold (1.30 log units) between middle value and limit.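

In this assay compound 3 gives > 6000 nM, which is a limit of the assay and not a number. The change to the 2H-tetrazol-5-yl gives an at least 46-fold higher number from compound 2 to compound 3 (1.66 log units; beyond the scatter), and the comparison with the 1-methoxyethyl group gives an at least 5.0-fold higher number from compound 1 to compound 3 (0.69 log units; beyond the scatter). Of the three groups on this aromatic carbon, acetyl therefore gives the strongest inhibition and the 2H-tetrazol-5-yl the weakest, so this position does not accept every replacement for acetyl.

Which feature of the 2H-tetrazol-5-yl weakens inhibition, and by how much beyond the limit, stays open. So does whether a carboxylic acid or an amide on this carbon would match acetyl.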